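A few compounds are considered here, and "the series" means these few. Any claim that something is new, unique, unknown or untested is made for them only; others in the source may bear on it.

Compound 3 `Cc1cc(C)c(Oc2cc(Nc3ccc(C#N)cc3)ncc2C(=O)NCc2cn(CCC#N)nn2)c(C)c1` carries a cyanomethyl on a saturated chain carbon bound to an aromatic nitrogen, and in an ADME assay on MT4 cells (Homo sapiens) for cytotoxicity, read by MTT assay, with a stated time of 5 days (a lower number here means that less compound is tolerated, a higher number that more compound is tolerated), compound 3 gives 40200 nM, the highest of the two numbers shown. Compound 2 `CC(=O)Cn1cc(CNC(=O)c2cnc(Nc3ccc(C#N)cc3)cc2Oc2c(C)cc(C)cc2C)nn1` gives 19400 nM in this assay, and the step is a 2.1-fold higher number from compound 2 to compound 3 (0.32 log units; beyond the scatter). Compound 1 `Cc1cc(C)c(Oc2cc(Nc3ccc(C#N)cc3)ncc2C(=O)NCc2cn(Cc3ccccc3C#N)nn2)c(C)c1` gives > 219000 nM, which is a limit of this assay. Compound 4 `Cc1cc(C)c(Oc2cc(Nc3ccc(C#N)cc3)ncc2C(=O)NCc2cn(Cc3ccccc3C)nn2)c(C)c1` differs from compound 3 by 2-methylphenyl in place of cyanomethyl on a saturated chain carbon bound to an aromatic nitrogen. The step that bears on this runs the other way, an at least 5.4-fold lower number from compound 1 to compound 3 (0.73 log units; beyond the scatter), and an at least 11-fold lower number from compound 1 to compound 2 (1.05 log units; beyond the scatter) points the same way, so putting an aryl group back on that carbon should raise the number. For compound 4 the expected step is therefore a 3.7-fold higher number from compound 3 to compound 4 (0.57 log units; beyond the scatter). Compound 4 is estimated at 150000 nM, between 60000 nM and 300000 nM, and may again be reported only as a limit.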

Compound 4, half-maximal cytotoxic concentration: >= 164000 nM
Compound 4 ended at the assay's limit (the forecaster's own chance of this, stated with the estimate: 45%); at least 1.0-fold (0.03 log units) between middle value and limit.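

With 2-methylphenyl on a saturated chain carbon bound to an aromatic nitrogen, this assay gives an at least 4.0-fold higher number from compound 3 to compound 4 (0.61 log units; beyond the scatter) and an at least 8.4-fold higher number from compound 2 to compound 4 (0.92 log units; beyond the scatter). Compound 4 stands at a limit, so an aryl group on that carbon can keep the number this high with no nitrile on the ring: the limit of >= 164000 nM in this assay, at which 1 of the 4 values shown sits. The step between compound 1 and compound 4 cannot be read, since both values are limits. Left open is how far the two aryl groups really differ, and where an amine or a carboxylic acid on that carbon would fall.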